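The source may hold more compounds than are shown below. What is called first, only, known or untested is meant among the compounds shown, and "the series" means these compounds.

The study compares three compounds built on a shared core, which differ only in the group carried on a saturated chain carbon bound to an aromatic carbon. Compound 1 `OC[C@H]1O[C@@H](n2cnc3c(COc4ccccn4)ncnc32)[C@H](O)[C@@H]1O` gives 10800 nM in a functional assay on CCRF-CEM cells (Homo sapiens) for inhibition, read by XTT assay, with a stated time of 72 h; on this read-out lower numbers stand for stronger inhibition and higher numbers for weaker inhibition; compound 2 `OC[C@H]1O[C@@H](n2cnc3c(CSCc4ccccc4)ncnc32)[C@H](O)[C@@H]1O` gives 4650 nM, and compound 3 `COCc1ncnc2c1ncn2[C@@H]1O[C@H](CO)[C@@H](O)[C@H]1O` gives 1140 nM. Compound 3 therefore stands at the lowest number of the three, both of the steps reaching it lying beyond the scatter: a 9.5-fold lower number from compound 1 to compound 3 (0.98 log units; beyond the scatter) and a 4.1-fold lower number from compound 2 to compound 3 (0.61 log units; beyond the scatter). Compound 4 `OC[C@H]1O[C@@H](n2cnc3c(Cn4ccc5ccccc54)ncnc32)[C@H](O)[C@@H]1O` is the next member; it differs from compound 3 by 1H-indol-1-yl in place of methoxy on a saturated chain carbon bound to an aromatic carbon. The two steps into compound 3 are the ones that bear on this change: in each, a small group on this carbon gave a lower number than a larger aromatic one. Moving from compound 3 to compound 4 is thus expected to raise the number by a modest amount, a 3.9-fold higher number from compound 3 to compound 4 (0.60 log units; beyond the scatter). Compound 4 is estimated at 4500 nM, within a range from 1500 nM to 15000 nM.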

Compound 4, half-maximal inhibitory concentration: 1960 nM
Beside the measured number, compound 4's estimate is 2.3-fold (0.36 log units) above it; low and high end bracket the measured number.
By their numbers in this assay, from the lowest: compounds 3 and 4 (each within the scatter of the next); then compound 2; then compound 1.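

In this assay, compound 4 shows that a large aromatic group on this saturated chain carbon need not cost activity relative to methoxy: the change gives a 1.7-fold higher number from compound 3 to compound 4 (0.24 log units; within the scatter). The same group also stands apart from the other two large groups, with a 2.4-fold lower number from compound 2 to compound 4 (0.38 log units; beyond the scatter) and a 5.5-fold lower number from compound 1 to compound 4 (0.74 log units; beyond the scatter). Among these compounds, then, which aromatic group is carried matters more than the mere presence of a large one, and compound 4 goes against the earlier trend of small over large. Nothing shown gives a reason for these differences. The compounds shown leave open where a simple amine, a carboxylic acid or a longer alkyl chain on this carbon would fall in this assay. They also leave open whether a substituted 1H-indol-1-yl would keep the number of compound 4.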